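This account rests on a few compounds, and the source may have more. Where it says the series, first, only, none or still open, it means among the compounds named here.

Measured in a functional assay on HL-60 cells (Homo sapiens) for antiproliferative activity, read by XTT assay, with a stated time of 72 h; on this read-out lower numbers stand for stronger inhibition and higher numbers for weaker inhibition:

- Compound 1 `C=C(C)CCC[C@]1(C)C2=CCC[C@](C)(CC(=O)c3ccoc3)[C@H]2CC[C@H]1C`: > 100000 nM
- Compound 2 `CC(C)=CCC[C@]1(C)C2=CCC[C@](C)(CC(=O)c3ccoc3)[C@H]2CC[C@H]1C`: 57800 nM
- Compound 3 `C=C(C)CC[C@]1(C)C2=CCC[C@](C)(C[C@@H](OC(C)=O)C3=CC(=O)OC3O)[C@H]2CC[C@H]1C`: 3300 nM

Compound 1 has no actual number in this assay, only a limit: it stands at the limit of > 100000 nM in this assay, at which 1 of the 3 values shown sits. The next compound, compound 4 `C=C(C)CCC[C@]1(C)C2=CCC[C@](C)(C[C@@H](O)c3ccoc3)[C@H]2CC[C@H]1C`, keeps the core and chains of compound 1 and alters one group, ((furan-3-yl)(hydroxy)methyl in place of (furan-3-yl)carbonyl on a saturated chain carbon bound to a saturated ring carbon). In words, (furan-3-yl)(hydroxy)methyl takes the place of (furan-3-yl)carbonyl on a saturated chain carbon bound to a saturated ring carbon.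

For the measured compounds named here, only one measured step starts from compound 1: an at least 1.7-fold lower number from compound 1 to compound 2 (0.23 log units; that floor lies within the scatter). That step swaps 2-methylprop-2-en-1-yl for 2-methylprop-1-en-1-yl and leaves the (furan-3-yl)carbonyl untouched, so it bears on the new change only indirectly. Going by the values given here, compound 3 gives 3300 nM, but it differs from compound 1 in more than one place and offers no single step to lean on. Among the compounds with values here, no measured step therefore sizes this change. Since compound 1 sits at a limit, any number for compound 4 would appear as a lower one, and a modest shift is expected, with a real chance of another reading at the limit. The expected step is an at least 2.0-fold lower number from compound 1 to compound 4 (0.30 log units; that floor lies within the scatter). For compound 4 the estimated value is 50000 nM, with an expected range of 15000 nM to 100000 nM.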

Compound 4, half-maximal inhibitory concentration: 31200 nM
The estimate for compound 4 lay 1.6-fold (0.20 log units) above the measured number; the range from low to high includes it.
By their numbers in this assay, from the lowest: compound 3; then compounds 4 and 2 (each within the scatter of the next). At a limit, above all of these: compound 1.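

In this assay, setting (furan-3-yl)(hydroxy)methyl in place of (furan-3-yl)carbonyl on a saturated chain carbon bound to a saturated ring carbon gives an at least 3.2-fold lower number from compound 1 to compound 4 (0.50 log units; beyond the scatter). This is the first change to the parent compound whose effect is shown to exceed the scatter, since the only earlier step, at the chain end, gave an at least 1.7-fold lower number from compound 1 to compound 2 (0.23 log units; that floor lies within the scatter). The new step can be read only as a floor, and its true size stays unknown because compound 1 has a limit rather than a number: the limit of > 100000 nM in this assay, at which 1 of the 4 values shown sits.

The compounds shown leave open whether the hydroxy group is itself what matters at this place, or whether an amine or a methyl ether on the same carbon would serve as well, and whether the opposite configuration at the new stereocentre would read the same. They also leave open whether the same exchange of carbonyl for hydroxy-bearing carbon would shift the number in the same direction on the 2-methylprop-1-en-1-yl chain of compound 2.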